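The source may report more compounds than this note shows. Statements on the series, on what has been measured and on what is new or still open speak of the compounds shown alone.

Among the compounds with values here, compound 1 `Cc1cc(N2CC[C@@H](C)[C@@H](N(C)c3ncnc4[nH]ccc34)C2)n2nc(SCc3ccccc3)nc2n1` is the only member of the series with a number rather than a limit in a toxicity assay on GES1 cells (Homo sapiens) for inhibition, read by MTT assay, with a stated time of 72 h; on this read-out lower numbers stand for stronger inhibition and higher numbers for weaker inhibition: compound 1 gives 67200 nM. Compound 2 `Cc1cc(N2CC[C@@H](C)[C@@H](N(C)c3ncnc4[nH]ccc34)C2)n2nc(SCc3ccc(Cl)cc3)nc2n1` carries chloro in place of hydrogen on an aromatic carbon, and in this assay compound 2 returns only a limit, > 100000 nM. The step is an at least 1.4-fold higher number from compound 1 to compound 2 (0.17 log units; that floor lies within the scatter), so the chloro change cannot be read as more than a floor; it sits at the limit of > 100000 nM in this assay, at which 1 of the 2 values shown sits.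

Compound 3 `Cc1ccc(CSc2nc3nc(C)cc(N4CC[C@@H](C)[C@@H](N(C)c5ncnc6[nH]ccc56)C4)n3n2)cc1` differs from compound 1 by methyl in place of hydrogen on an aromatic carbon. Within the data shown here, the only measured step bearing on it is the chloro case, in which a small group entered at the same kind of aromatic carbon and the number from compound 1 to compound 2 moved, if at all, toward weaker inhibition by an amount whose floor is within the scatter. A methyl entering where chloro entered is expected to behave alike: the step of a 1.3-fold higher number from compound 1 to compound 3 (0.13 log units; within the scatter) is expected to lean toward weaker inhibition but not beyond the scatter. Compound 3 is therefore estimated at 90000 nM in this assay, within 40000 nM to 200000 nM, with a fair chance that only a limit is reported.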

Compound 3, half-maximal inhibitory concentration: 82500 nM
Estimate against measurement, compound 3: 1.1-fold (0.04 log units) above; the measured number falls inside the stated range.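

Compound 3 gives the series a first number, rather than a limit, for a substituent at this carbon of the benzyl ring, para to a large group: a 1.2-fold higher number from compound 1 to compound 3 (0.09 log units; within the scatter). In this assay, methyl in place of hydrogen therefore leaves compound 3 indistinguishable from the unsubstituted compound 1, a reading that the chloro step, open at one end, could not give. Methyl and chloro are not separated at this position either, with an at least 1.2-fold lower number from compound 2 to compound 3 (0.08 log units; that floor lies within the scatter). For compound 2 the reading remains a limit and not a number: the limit of > 100000 nM in this assay, at which 1 of the 3 values shown sits.

On these data alone, whether an amine or a carboxylic acid at this same carbon would bring the number in this assay clearly away from that of compound 1 stays open. Also open, as far as these compounds go, is whether a longer chain in place of the methyl would keep the reading within the scatter of compound 1 or take it to a limit, as with compound 2.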